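Half-life of compound 4 after swapping the arylmethyl thioether

The source may hold more compounds than are shown below. What is called first, only, known or untested is meant among the compounds shown, and "the series" means these compounds.

Compounds measured in an ADME assay on microsomes from liver (Homo sapiens) for metabolic stability, read by LC-MS, using NADPH, tested at 5 uM; a higher number here means that the compound lasts longer, a lower number that the compound disappears faster:
compound 1, `Cc1cc(-c2ccccc2)n(/C(N)=N/S(=O)(=O)c2cc(C)c(Cl)cc2SCc2ccccc2C(F)(F)F)n1`, 0.306 h
compound 2, `Cc1cc(-c2ccccc2)n(/C(N)=N/S(=O)(=O)c2cc(C)c(Cl)cc2SCc2cccc3ccccc23)n1`, 0.256 h
compound 3, `Cc1cc(S(=O)(=O)/N=C(\N)n2nccc2-c2ccccc2)c(SCc2cccc3ccccc23)cc1Cl`, 0.268 h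

Compound 2 gives the lowest of the three numbers in this assay, but its separation from the others is slight: the nearest is compound 3, and the step of a 1.0-fold higher number from compound 2 to compound 3 (0.02 log units; within the scatter); the furthest is compound 1, and the step of a 1.2-fold lower number from compound 1 to compound 2 (0.08 log units; within the scatter). All three half-lives therefore sit in one band.

Compound 4, `Cc1cccc(CSc2cc(Cl)c(C)cc2S(=O)(=O)/N=C(\N)n2nc(C)cc2-c2ccccc2)c1`, has not yet been measured. It differs from compound 2 in one place: 3-methylphenyl in place of naphthalen-1-yl on a saturated chain carbon bound to a sulfur.

For the measured compounds named here, the step that bears most directly on this change is the one from compound 1 to compound 2, where a different aryl group was exchanged at the very same saturated chain carbon bound to a sulfur, and that step, a 1.2-fold lower number from compound 1 to compound 2 (0.08 log units; within the scatter), stayed within the scatter. The step of a 1.0-fold higher number from compound 2 to compound 3 (0.02 log units; within the scatter), at an aromatic carbon, likewise stayed within the scatter. With two exchanges of this kind leaving the half-life essentially unmoved, no step beyond the scatter is expected for compound 4 in this assay, in either direction.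

Compound 4 is therefore estimated at 0.29 h, with a range of 0.15 h to 0.6 h, an expected step of a 1.1-fold higher number from compound 2 to compound 4 (0.05 log units; within the scatter).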

Compound 4, half-life: 0.214 h
Compound 4: middle estimate off by 1.4-fold (0.13 log units), on the high side, within the range that was stated.
By their numbers in this assay, from the lowest: compounds 4, 2, 3 and 1 (each within the scatter of the next).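

In this assay, going from the two aromatic rings of naphthalen-1-yl to the single ring of 3-methylphenyl, with 10 heavy atoms giving way to 7, left the half-life within the scatter (a 1.2-fold lower number from compound 2 to compound 4 (0.08 log units; within the scatter)). The exchange of 2-(trifluoromethyl)phenyl for 3-methylphenyl at the same saturated chain carbon bound to a sulfur also stayed within the scatter (a 1.4-fold lower number from compound 1 to compound 4 (0.16 log units; within the scatter)), so the three aryl groups shown at this place now share one band, and the loss of an aromatic ring did not move the half-life out of it. Nothing available here accounts for this flat result.

Every group shown at this place is an aryl group, which leaves open what an amine or a carboxylic acid on that ring, or a longer chain between the ring and the sulfur, would do to the half-life. The exchange of methyl for hydrogen on an aromatic carbon is shown only with naphthalen-1-yl, so whether it would also stay within the scatter with 3-methylphenyl remains open.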